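A fluoro for a methyl: expecting compound 4

A few compounds are considered here, and "the series" means these few. Any claim that something is new, unique, unknown or untested is made for them only; others in the source may bear on it.

- Compound 1 `CC(=O)c1ccc(/N=C2\C=C(OCc3cn(S(=O)(=O)c4ccc(C)cc4)nn3)C(=O)c3ccccc32)cc1` gives 5520 nM in a functional assay on K562 cells (Homo sapiens) for cytotoxicity, read by MTT assay, with a stated time of 72 h; on this read-out lower numbers stand for stronger inhibition and higher numbers for weaker inhibition
- Compound 2 `Cc1ccc(S(=O)(=O)n2cc(COC3=C/C(=N\c4ccc(I)cc4)c4ccccc4C3=O)nn2)cc1` gives 10800 nM in this assay
- Compound 3 `Cc1ccc(/N=C2\C=C(OCc3cn(S(=O)(=O)c4ccc(C)cc4)nn3)C(=O)c3ccccc32)cc1` gives 6220 nM in this assay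

Compound 3 holds the middle one of the three numbers at 6220 nM and lies within the scatter of both other compounds. The change to compound 4 `Cc1ccc(S(=O)(=O)n2cc(COC3=C/C(=N\c4ccc(F)cc4)c4ccccc4C3=O)nn2)cc1` is fluoro in place of methyl on an aromatic carbon and in words it is fluoro in place of methyl on an aromatic carbon, para to a large group. Within the data shown here, no fluoro compound has a measured value yet, so the evidence comes from the steps that exchange the group at this same place. These are a 1.1-fold higher number from compound 1 to compound 3 (0.05 log units; within the scatter) and a 1.7-fold lower number from compound 2 to compound 3 (0.24 log units; within the scatter) and also a 2.0-fold higher number from compound 1 to compound 2 (0.29 log units; within the scatter) and each of them stays within the scatter. Acetyl, iodo and methyl therefore give no separation here, and no step beyond the scatter is expected for fluoro in this assay either. The expected step is a 1.1-fold higher number from compound 3 to compound 4 (0.05 log units; within the scatter) and no firm direction is claimed for it. For compound 4 the estimated value is 7000 nM with 3500 nM to 14000 nM as its expected range.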

Compound 4, half-maximal inhibitory concentration: 7700 nM
Compound 4: middle estimate off by 1.1-fold (0.04 log units), on the low side; measured number inside the range.
By their numbers in this assay, from the lowest: compounds 1, 3, 4 and 2 (each within the scatter of the next).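

Fluoro at this place, para to a large group, also fails to separate from the other groups in this assay: the steps read (a 1.2-fold higher number from compound 3 to compound 4 (0.09 log units; within the scatter)), (a 1.4-fold lower number from compound 2 to compound 4 (0.15 log units; within the scatter)) and (a 1.4-fold higher number from compound 1 to compound 4 (0.14 log units; within the scatter)). Among these compounds, the flat picture seen with acetyl, iodo and methyl therefore extends to a fourth group, as every step from compound 4 to the earlier compounds stays within the scatter. Nothing shown here offers an explanation for this lack of separation.

The compounds shown leave open whether any group at this place would give a step beyond the scatter, for instance an amine, a carboxylic acid or a longer chain. They also leave open whether changes elsewhere on the shared core would separate the compounds in this assay.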